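A few compounds are considered here, and "the series" means these few. Any claim that something is new, unique, unknown or untested is made for them only; others in the source may bear on it.

Compound 1 (`CS(=O)(=O)c1cccc(-c2ccc3nccc(-c4ccncc4)c3n2)c1`) and compound 2 (`O=S(=O)(NCCN1CCCC1)c1cccc(-c2ccc3nccc(-c4ccnc(C(F)(F)F)c4)c3n2)c1`) were both tested in an ADME assay on CHO cells (Cricetulus griseus) for cytotoxicity, read by MTT assay; a lower number here means a stronger inhibitor, a higher number a weaker inhibitor. In that assay compound 1 gives 13000 nM, and compound 2 gives 13000 nM; the two values sit level with each other, within the scatter of the measurement, so nothing separates them at the digits reported. Compound 3 (`O=S(=O)(c1cccc(-c2ccc3nccc(-c4ccncc4)c3n2)c1)N1CC[C@H](O)C1`) has not yet been measured in this assay. It differs from compound 1 in one place: 3-hydroxypyrrolidin-1-yl in place of methyl on a sulfonyl sulfur. For the measured compounds named here, no measured pair in this set carries this change on its own, so there is no step to copy. Given that compound 1 and compound 2, which differ at the sulfonyl group and elsewhere, give the same reading, the step from compound 1 to compound 3 is expected to be small, no change at the digits printed from compound 1 to compound 3 (within the scatter), with no direction beyond the scatter. Compound 3 is therefore estimated at 13000 nM, within a range of 5000 nM to 35000 nM.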

Compound 3, half-maximal inhibitory concentration: 9000 nM
Estimate against measurement, compound 3: 1.4-fold (0.16 log units) above, and the stated range covers the measured number.
By their numbers in this assay, from the lowest: compounds 3, 1 and 2 (each within the scatter of the next).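

In this assay, 3-hydroxypyrrolidin-1-yl in place of methyl on a sulfonyl sulfur gives a 1.4-fold lower number from compound 1 to compound 3 (0.16 log units; within the scatter). For the compounds shown here, this is the first step in the set that carries a change at this position on its own, and it shows that a single carbon can give way to a ring bearing a hydrogen-bond donor and a defined stereocentre without the reading moving beyond the scatter. Nothing available here accounts for this result.

The compounds shown leave open whether the hydroxyl contributes anything of its own, which a plain pyrrolidin-1-yl group would test, and whether the opposite stereocentre reads the same. They also leave open whether a carboxylic acid, a primary amine or a longer alkyl chain on the sulfonyl sulfur would stay equally close to compound 1.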